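The source may hold more compounds than are shown below. What is called first, only, known or untested is meant among the compounds shown, and "the series" means these compounds.

Working notes on the series. In a functional assay on K562 cells (Homo sapiens) for cytotoxicity, read by flow cytometry, with a stated time of 72 h (on this read-out lower numbers stand for stronger inhibition and higher numbers for weaker inhibition), compound 1 (`Cc1ccc(S(=O)(=O)Cc2nc(Nc3ccccc3)c3ccccc3n2)cc1`) stands at ("nd(insoluble)" (no result reported)), so it has no single number to start from. The nearest measured compound is compound 2 (`Cc1ccc(S(=O)(=O)Cc2nc(Nc3ccccc3Cl)c3ccccc3n2)cc1`), which gives (24000 nM). Compound 3 (`Cc1ccc(S(=O)(=O)Cc2nc(Nc3ccccc3)c3cc([N+](=O)[O-])ccc3n2)cc1`) has nitro in place of hydrogen on an aromatic carbon of the shared core (nitro in place of hydrogen on an aromatic carbon). With no measured start, the step in this assay cannot be sized. A modest shift toward stronger inhibition is expected, measured against compound 2 at (24000 nM). The estimated value for compound 3 is 12000 nM (expected range 3000 nM to 40000 nM).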

Compound 3, half-maximal inhibitory concentration: > 125000 nM
Compound 3: only a limit was reported (the forecaster's own chance of this, stated with the estimate: 30%); middle value at least 10-fold (1.01 log units) from the limit.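

No step can be read from compound 1 to compound 3: compound 1 has no single number, and compound 3 gives only a limit, > 125000 nM. The compounds shown leave open how far nitro in place of hydrogen on the shared core shifts cytotoxicity.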